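The source may hold more compounds than are shown below. What is called first, only, known or untested is meant among the compounds shown, and "the series" means these compounds.

Working notes on the series.

Within the data shown here, compound 3 `CCCCCCCCS(=O)(=O)Nc1ccc(-c2ccc(Cl)cc2)cc1C(=O)O` gives 9200 nM in an assay on mitochondria (strain BALB/c) for inhibition of glycerol-3-phosphate acyltransferase 1, mitochondrial (Mus musculus), read by scintillation counting, with a stated time of 10 min (on this read-out higher numbers stand for weaker inhibition and lower numbers for stronger inhibition), the lowest of the three numbers so far. Compound 1 `CCCCCCCCS(=O)(=O)Nc1cc(-c2ccc(OC)cc2)ccc1C(=O)O` gives 13300 nM, which sits within the scatter of compound 3, so no order between those two is claimed. Compound 2 `CCCCCCCCS(=O)(=O)Nc1cc(-c2ccccc2O)ccc1C(=O)O` gives 63100 nM, the furthest from compound 3 and beyond the scatter.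

Compound 4 `CCCCCCCCS(=O)(=O)Nc1ccc(-c2ccccc2O)cc1C(=O)O` is the next one to be measured. Relative to compound 3 the change is 2-hydroxyphenyl in place of 4-chlorophenyl on an aromatic carbon. Among the measured compounds shown here, the one step already seen that bears on it is the switch to 2-hydroxyphenyl on the core of compound 1, where a 4.7-fold higher number from compound 1 to compound 2 (0.68 log units; beyond the scatter) was found. That step replaced a 4-methoxyphenyl rather than a 4-chlorophenyl and sat on a different core, so it transfers only loosely; still, it is the only direct read on a 2-hydroxyphenyl in this set and it went clearly toward weaker inhibition. A shift of comparable size and the same direction is therefore expected for compound 4 in this assay, with wide uncertainty because the anchor is a single pair.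

For compound 4 the expected step is a 4.0-fold higher number from compound 3 to compound 4 (0.60 log units; beyond the scatter), giving an estimate of 37000 nM with a range from 12000 nM to 110000 nM.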

Compound 4, half-maximal inhibitory concentration: 61700 nM
Compound 4: middle estimate off by 1.7-fold (0.22 log units), on the low side; measured number inside the range.
By their numbers in this assay, from the lowest: compounds 3 and 1 (each within the scatter of the next); then compounds 4 and 2 (each within the scatter of the next).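

In this assay, a 6.7-fold higher number from compound 3 to compound 4 (0.83 log units; beyond the scatter) shows that 2-hydroxyphenyl also goes with weaker inhibition when it replaces 4-chlorophenyl, on a different core from the earlier pair. The direction seen in a 4.7-fold higher number from compound 1 to compound 2 (0.68 log units; beyond the scatter) therefore now rests on two pairs with different departing groups, and no compound shown goes against it, though two pairs make only a narrow pattern. With 2-hydroxyphenyl on both cores, compound 2 gives 63100 nM and compound 4 gives 61700 nM, two values within the scatter of each other, so the shift in attachment between these two compounds shows no measurable difference in this assay. Nothing measured in this set speaks to the reason for these shifts.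

Still open, going by these compounds, is whether the higher numbers track the arrival of the hydroxy group, its place on the ring, or the loss of the 4-chloro or 4-methoxy substituent, since each pair changes these together. An unsubstituted phenyl, a 4-hydroxyphenyl or a 2-methoxyphenyl on the core of compound 3 would separate these readings.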